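Swapping the pyrazole amine for a methoxyphenyl amine

The compounds below may be only part of what the source reports. "The series", "measured", "known", "first", "only" and "open" are said of these compounds alone.

Of the compounds shown here, three that share one core have been measured in a functional assay on A549 cells (Homo sapiens) for antiproliferative activity, read by MTT assay, with a stated time of 72 h (a higher number here means a weaker inhibitor, a lower number a stronger inhibitor), and they differ only in the chain attached to the amide. Compound 1 `C/C=C/C(=O)Nc1cccc(Oc2nc(Nc3ccn(C)n3)nc3c2CSCC3)c1` gives > 50000 nM, which is a limit of the assay and not a number; it sits at the limit of > 50000 nM in this assay, at which 1 of the 3 values shown sits, so for compound 1 only a limit is known. Compound 2 `CC/C=C/C(=O)Nc1cccc(Oc2nc(Nc3ccn(C)n3)nc3c2CSCC3)c1` gives 36800 nM, and compound 3 `CCC/C=C/C(=O)Nc1cccc(Oc2nc(Nc3ccn(C)n3)nc3c2CSCC3)c1` gives 8190 nM. Lengthening the chain lowers the number: an at least 1.3-fold lower number from compound 1 to compound 2 (0.13 log units; that floor lies within the scatter), an at least 6.1-fold lower number from compound 1 to compound 3 (0.78 log units; beyond the scatter), and a 4.5-fold lower number from compound 2 to compound 3 (0.65 log units; beyond the scatter). Compound 3 thus stands lowest of the two numbers shown, with compound 2 its nearest neighbour.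

Compound 4 `CCC/C=C/C(=O)Nc1cccc(Oc2nc(Nc3ccc(OC)cc3)nc3c2CSCC3)c1` keeps the chain of compound 3 and changes the other end of the molecule instead: 4-methoxyphenyl in place of 1-methyl-1H-pyrazol-3-yl on a nitrogen on an aromatic ring. None of the three measured steps touches this part of the core; all of them concern the amide chain, so they give no guide to the size or direction of this change. In this assay the number for compound 4 is therefore expected to stay close to that of compound 3, with a wide margin in either direction. Compound 4 is estimated at 7000 nM, with a range from 1500 nM to 30000 nM. The step this implies, a 1.2-fold lower number from compound 3 to compound 4 (0.07 log units; within the scatter), is an expectation only.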

Compound 4, half-maximal inhibitory concentration: 11900 nM
Beside the measured number, compound 4's estimate is 1.7-fold (0.23 log units) below it, within the range that was stated.
By their numbers in this assay, from the lowest: compounds 3 and 4 (each within the scatter of the next); then compound 2. At a limit, above all of these: compound 1.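

In this assay, 4-methoxyphenyl in place of 1-methyl-1H-pyrazol-3-yl on a nitrogen on an aromatic ring gives a 1.5-fold higher number from compound 3 to compound 4 (0.16 log units; within the scatter), so this pair cannot be told apart in this assay. The two groups differ in ring size, in the atoms of the ring and in their hydrogen-bond acceptors, yet with the chain of compound 3 held fixed, this first change at this position stays within the scatter, unlike the step from compound 2 to compound 3 along the amide chain. Nothing measured here bears on why these two groups give numbers so close together.

On these data alone, the result rests on one pair with one chain, so whether lengthening the chain would lower the number with 4-methoxyphenyl in place, as it does from compound 2 to compound 3 with 1-methyl-1H-pyrazol-3-yl, remains open. Also open, as far as these compounds go, is whether this position would stay as undiscriminating for a group of a different kind on the same nitrogen, such as a phenyl ring carrying a carboxylic acid or a piperazine.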